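This account rests on a few compounds, and the source may have more. Where it says the series, first, only, none or still open, it means among the compounds named here.

Measured in a functional assay on HCT-116 cells (Homo sapiens) for cytotoxicity, read by MTT assay, with a stated time of 72 h; a lower number here means a stronger inhibitor, a higher number a weaker inhibitor:
Compound 1 `O=C(NCCCNc1c(C(=O)NCc2ccc(F)cc2)nc(Br)c2cccnc12)c1ccccc1`: > 10000 nM (a limit of the assay, not a number)
Compound 2 `CNCCCNc1c(C(=O)NCc2ccc(F)cc2)nc(Br)c2cccnc12`: 9000 nM

For the measured compounds named here, compound 2 holds the only actual number so far, and the other result is a limit. Compound 3 `O=C(NCc1ccc(F)cc1)c1nc(Br)c2cccnc2c1NCc1ccccc1` differs from compound 2 as follows: phenyl in place of 2-(methylamino)ethyl on a saturated chain carbon bound to a nitrogen on an aromatic ring. In words, this is phenyl in place of 2-(methylamino)ethyl on a saturated chain carbon bound to a nitrogen on an aromatic ring. Going by the values given here, only one measured step bears on this change, an at least 1.1-fold lower number from compound 1 to compound 2 (0.04 log units; that floor lies within the scatter), where methyl replaces benzoyl on an amine nitrogen. It is a floor rather than a measured size, and it concerns a different exchange, so it gives no ground to expect a large move in either direction. The change expected in this assay is therefore none beyond the scatter, though a result reported only as a limit would be no surprise given (the limit of > 10000 nM in this assay, at which 1 of the 2 values shown sits). The expected step is a 1.1-fold higher number from compound 2 to compound 3 (0.05 log units; within the scatter). For compound 3 the estimate is 10000 nM, with an expected range from 3500 nM to 30000 nM.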

Compound 3, half-maximal inhibitory concentration: > 20000 nM
Compound 3 ended at the assay's limit; the forecaster's own chance of this, stated with the estimate: 50%; middle value at least 2.0-fold (0.30 log units) away from the limit.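

In this assay, this position now gives its first step beyond the scatter: an at least 2.2-fold higher number from compound 2 to compound 3 (0.34 log units; beyond the scatter), with phenyl in place of 2-(methylamino)ethyl on a saturated chain carbon bound to a nitrogen on an aromatic ring. The exchange of 3-(methylamino)propyl for benzyl moves the result towards a weaker inhibitor, but the size of that move is only a floor: the limit of > 20000 nM in this assay, at which 1 of the 3 values shown sits. The step between compound 1 and compound 3 cannot be read.

The compounds shown leave open whether the loss of the methylamino nitrogen or the arrival of the phenyl ring accounts for the step. As far as these compounds go, a plain propyl group or a 3-aminopropyl group in place of benzyl would bear on that question, and how far a compound of this series can fall below the value of compound 2 also remains open.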